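The source may hold more compounds than are shown below. What is called first, only, known or untested is meant among the compounds shown, and "the series" means these compounds.

The measured compounds are compound 1 `c1cncc(N2C[C@H]3CCNC[C@H]32)c1`, compound 2 `N#Cc1cncc(N2C[C@H]3CCNC[C@H]32)c1` and compound 3 `COc1cncc(N2C[C@@H]3CCNC[C@@H]32)c1`. In a functional assay on HEK293 cells for agonist activity at Neuronal acetylcholine receptor; alpha4/beta2 (Homo sapiens), read by FLIPR (a higher number here means that more compound is needed for the effect, a lower number that less compound is needed), compound 1 gives 1400 nM, compound 2 gives 1930 nM, and compound 3 gives 7690 nM, the highest of the three numbers, with the other two lying beyond the scatter of it.

Among the measured compounds shown here, the one step within this set, a 1.4-fold higher number from compound 1 to compound 2 (0.14 log units; within the scatter), replaces hydrogen by cyano and stays within the scatter. Compound 4 `COc1cncc(N2C[C@H]3CCNC[C@H]32)c1` is the unmeasured compound; relative to compound 3 the change is the two compounds have the same atoms and bonds and differ only in configuration as drawn: 2 of 2 stereo elements differ (all stereocentres are inverted: mirror images); a stereocentre at a saturated ring carbon is drawn S in compound 3 and R in compound 4; a stereocentre at a saturated ring carbon is drawn R in compound 3 and S in compound 4. For the measured compounds named here, no measured pair shows the effect of inverting both stereocentres, so no step bears directly on it. What the data do show is that compound 1 and compound 2, which carry the configuration drawn for compound 4, give lower numbers in this assay than compound 3. Compound 4 is therefore expected to come in with a lower number than compound 3, a step of about a 4.3-fold lower number from compound 3 to compound 4 (0.63 log units; beyond the scatter), with the size uncertain. The estimate for compound 4 is 1800 nM, within 500 nM to 7000 nM.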

Compound 4, half-maximal effective concentration: 1110 nM
Compound 4: middle estimate off by 1.6-fold (0.21 log units), on the high side, and the stated range covers the measured number.
By their numbers in this assay, from the lowest: compounds 4, 1 and 2 (each within the scatter of the next); then compound 3.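

In this assay, inverting both stereocentres gives a 6.9-fold lower number from compound 3 to compound 4 (0.84 log units; beyond the scatter), the first measured effect of configuration among these compounds, and the step belongs to configuration alone because nothing else separates the pair: the fact that compounds 3 and 4 differ only in the configuration as drawn. With the configuration drawn for compound 4, the group on the aromatic carbon makes little difference: methoxy in place of hydrogen gives a 1.3-fold lower number from compound 1 to compound 4 (0.10 log units; within the scatter), and methoxy in place of cyano gives a 1.7-fold lower number from compound 2 to compound 4 (0.24 log units; within the scatter). Hydrogen, cyano and methoxy are therefore not told apart at this position in this configuration.

The compounds shown carry only methoxy in the mirror-image configuration, so whether inversion has a similar effect with hydrogen or cyano stays open. Also open, as far as these compounds go, is whether an amine, a carboxylic acid or a longer alkoxy chain on that aromatic carbon would stand apart from these three groups.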